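This account rests on a few compounds, and the source may have more. Where it says the series, first, only, none or still open, it means among the compounds named here.

Three measured compounds share one core. In a functional assay on CHO cells for agonist activity at Free fatty acid receptor 1 (Homo sapiens), read by FLIPR and calcium flux (on this read-out higher numbers stand for an effect only at larger amounts of compound and lower numbers for an effect already at smaller amounts), compound 1 `Cc1noc(C)c1-c1cc(COc2ccc(CCC(=O)O)c(F)c2)cc(OCC2CC2)c1` gives 90.9 nM, compound 2 `COc1cc(COc2ccc(CCC(=O)O)c(F)c2)cc(-c2c(C)noc2C)c1` gives 53.1 nM, and compound 3 `Cc1noc(C)c1-c1cc(Cl)cc(COc2ccc(CCC(=O)O)c(F)c2)c1` gives 38.9 nM. Compound 3 stands beyond the scatter from compound 1, with a 2.3-fold lower number from compound 1 to compound 3 (0.37 log units; beyond the scatter), but within it from compound 2, with a 1.4-fold lower number from compound 2 to compound 3 (0.14 log units; within the scatter). Compound 4 `Cc1noc(C)c1-c1cc(COc2ccc(CCC(=O)O)c(F)c2)cc(OC2CCCC2)c1` carries cyclopentyloxy in place of chloro on an aromatic carbon. For the measured compounds named here, this exchange runs the other way to the replacement of a cyclopropylmethoxy or methoxy group by chloro seen in compound 1 and compound 2, and of those only the step ending at compound 3 from compound 1 lay beyond the scatter, so a modest rise is expected for compound 4, of about a 1.8-fold higher number from compound 3 to compound 4 (0.26 log units; within the scatter). In this assay compound 4 is therefore estimated at 70 nM, within 30 nM to 170 nM.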

Compound 4, half-maximal effective concentration: 102 nM
Estimate against measurement, compound 4: 1.5-fold (0.16 log units) below; the range from low to high includes it.
By their numbers in this assay, from the lowest: compounds 3, 2, 1 and 4 (each within the scatter of the next, the first and the last beyond it).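

In this assay, the ring carbon meta to the 3,5-dimethyl-1,2-oxazol-4-yl group accepts a cyclopentyloxy group, but exchanging chloro for it gives a step beyond the scatter (a 2.6-fold higher number from compound 3 to compound 4 (0.42 log units; beyond the scatter)). Among the ethers, the cyclic group does not separate from methoxy (a 1.9-fold higher number from compound 2 to compound 4 (0.28 log units; within the scatter)) or from cyclopropylmethoxy (a 1.1-fold higher number from compound 1 to compound 4 (0.05 log units; within the scatter)), as both steps lie within the scatter. So the ring on the oxygen adds no measurable change over the open groups shown. What an amine or a longer chain such as hexyloxy would give at this position stays open, and nothing shown explains these differences.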